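Series notes: 2,6-disubstituted aryl hydrazides on the shared core

The source may hold more compounds than are shown below. What is called first, only, known or untested is meant among the compounds shown, and "the series" means these compounds.

Among the compounds with values here, compound 2 `Cc1cccc(C)c1C(=O)NNC(=O)C1(C(=O)N[C@H]2CC(=O)OC2O)CCCCC1` stands at the lower end of the two numbers so far: in an assay on isolated protein for inhibition of Caspase-8 (Homo sapiens) (a higher number here means a weaker inhibitor, a lower number a stronger inhibitor), compound 2 gives 230 nM, whereas compound 1 `COc1cccc(C(=O)NNC(=O)C2(C(=O)N[C@H]3CC(=O)OC3O)CCCCC2)c1` gives 1800 nM in this assay. Within the data shown here, the one step measured, a 7.8-fold lower number from compound 1 to compound 2 (0.89 log units; beyond the scatter), is the only comparison available. Compound 3 `COc1cccc(OC)c1C(=O)NNC(=O)C1(C(=O)N[C@H]2CC(=O)OC2O)CCCCC1` differs from compound 2 in one place: 2,6-dimethoxyphenyl in place of 2,6-dimethylphenyl on a carbonyl carbon. Among the measured compounds shown here, the measured step bears on it only loosely, since it changed both the substituents and where they sit, and no step in this assay separates the two. The change from compound 2 to compound 3 keeps the substitution pattern and exchanges the groups, so a step of modest size in either direction, or none beyond the scatter, is expected, with the estimate leaning slightly toward a higher number: a 1.7-fold higher number from compound 2 to compound 3 (0.24 log units; within the scatter). Compound 3 is estimated at 400 nM in this assay, within a range of 120 nM to 1500 nM.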

Compound 3, half-maximal inhibitory concentration: 300 nM
Beside the measured number, compound 3's estimate is 1.3-fold (0.12 log units) above it, within the range that was stated.
By their numbers in this assay, from the lowest: compounds 2 and 3 (each within the scatter of the next); then compound 1.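

In this assay, the exchange of 2,6-dimethylphenyl for 2,6-dimethoxyphenyl on this carbonyl carbon gives a 1.3-fold higher number from compound 2 to compound 3 (0.12 log units; within the scatter), so the two groups cannot be told apart here, even though only 2,6-dimethoxyphenyl carries hydrogen-bond acceptors. The step of a 6.0-fold lower number from compound 1 to compound 3 (0.78 log units; beyond the scatter) lies beyond the scatter, which shows that the difference from the 3-methoxyphenyl compound holds for two different 2,6-disubstituted groups and not for 2,6-dimethylphenyl alone. No evidence is available that accounts for these numbers.

The compounds shown do not separate the substitution pattern from the number of substituents, since the steps from compound 1 change both at once. Also open, as far as these compounds go, is how a phenyl ring bearing chlorine atoms, or an unsubstituted phenyl, would read on the same carbonyl carbon in this assay.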